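Moving the bromine on the hydrazone ring: compound 3 to compound 4

The source may report more compounds than this note shows. Statements on the series, on what has been measured and on what is new or still open speak of the compounds shown alone.

Three measured compounds share one core and differ only in the ring attached to the carbon that is double-bonded to nitrogen. Compound 1 `Cc1ccc(O)c(/C=N\NC(=O)c2oc3cccc(O)c3c2C)c1` gives 5990 nM in a functional assay on MGC-803 cells (Homo sapiens) for inhibition, read by MTT assay; on this read-out lower numbers stand for stronger inhibition and higher numbers for weaker inhibition. Compound 2 `Cc1c(C(=O)N/N=C\c2cc(F)ccc2O)oc2cccc(O)c12` gives 5230 nM, and compound 3 `Cc1c(C(=O)N/N=C\c2ccc(Br)cc2O)oc2cccc(O)c12` gives 5460 nM; compound 3 thus lies between the other two, with every gap within the scatter. Compound 4 `Cc1c(C(=O)N/N=C\c2cccc(Br)c2O)oc2cccc(O)c12` differs from compound 3 by 3-bromo-2-hydroxyphenyl in place of 4-bromo-2-hydroxyphenyl on a carbon with a double bond to nitrogen. For the measured compounds named here, the steps that bear on this are a 1.1-fold lower number from compound 1 to compound 3 (0.04 log units; within the scatter) and a 1.0-fold higher number from compound 2 to compound 3 (0.02 log units; within the scatter), both changes on the same ring that left the number essentially unmoved. The step of a 1.0-fold higher number from compound 3 to compound 4 (0.00 log units; within the scatter) is therefore expected to be small. Compound 4 is estimated at 5500 nM, within 2500 nM to 12000 nM.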

Compound 4, half-maximal inhibitory concentration: 14200 nM
For compound 4 the middle estimate is 2.6-fold (0.41 log units) below the measured one, and the stated range ends below it.
By their numbers in this assay, from the lowest: compounds 2, 3 and 1 (each within the scatter of the next); then compound 4.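

In this assay, the change from 4-bromo-2-hydroxyphenyl to 3-bromo-2-hydroxyphenyl gives a 2.6-fold higher number from compound 3 to compound 4 (0.42 log units; beyond the scatter) even though both groups contain the same atoms, so here the place of the bromine matters, which the earlier changes on this ring did not reveal. Compound 4 also stands apart from the other two compounds, with a 2.7-fold higher number from compound 2 to compound 4 (0.43 log units; beyond the scatter) and a 2.4-fold higher number from compound 1 to compound 4 (0.37 log units; beyond the scatter) in the same direction. From the compounds shown here alone, whether an amine or a methoxy group in place of the bromine of 3-bromo-2-hydroxyphenyl would give a similar number remains open. Nothing available explains why moving the bromine weakens inhibition.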